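Trimming an aminomethyl to an amino on a pyrrolidine

This account rests on a few compounds, and the source may have more. Where it says the series, first, only, none or still open, it means among the compounds named here.

Compound 2 `NC[C@@H]1CCN(c2cc3c(cc2F)c(=O)c(C(=O)O)cn3Cc2ccc(-c3ccccc3)cc2)C1` gives the lowest number of the three measured compounds in an assay on isolated protein for inhibition of DNA topoisomerase 1 (Homo sapiens), with a stated time of 15 min (a lower number here means a stronger inhibitor, a higher number a weaker inhibitor), at 15600 nM. Compound 1 `O=C(O)c1cn(Cc2ccc(-c3ccccc3)cc2)c2cc(N3CC4CNCC4C3)c(F)cc2c1=O` gives 33300 nM, and compound 3 `NC[C@@H]1CCN(c2cc3c(cc2F)c(=O)c(C(=O)O)cn3Cc2ccc(-c3ccc(F)cc3)cc2)C1` gives 69600 nM. The two known steps are a 2.1-fold lower number from compound 1 to compound 2 (0.33 log units; beyond the scatter) and a 4.5-fold higher number from compound 2 to compound 3 (0.65 log units; beyond the scatter).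

Compound 4 `N[C@@H]1CCN(c2cc3c(cc2F)c(=O)c(C(=O)O)cn3Cc2ccc(-c3ccccc3)cc2)C1` differs from compound 2 only in the pyrrolidine substituent: amino in place of aminomethyl on a saturated ring carbon. Neither measured step touches this position; one changed the whole saturated ring system and the other added a fluoro on the distal aromatic ring, so they speak to the size of steps in this series but not to its direction here. Both were modest, and the change to compound 4 is a small one, so a step within or only slightly beyond the scatter is expected, in no firm direction.

Compound 4 is therefore expected to give about 22000 nM in this assay, in a range from 8000 nM to 60000 nM, which would mean a 1.4-fold higher number from compound 2 to compound 4 (0.15 log units; within the scatter).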

Compound 4, half-maximal inhibitory concentration: 63600 nM
For compound 4 the middle estimate is 2.9-fold (0.46 log units) below the measured one; measured number above the stated range.
By their numbers in this assay, from the lowest: compound 2; then compounds 1, 4 and 3 (each within the scatter of the next, the first and the last beyond it).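

Neither earlier step touched this position, and now it is clear that the substituent on this saturated ring carbon matters in this assay: shortening aminomethyl to amino, with the ring left unchanged, gives a 4.1-fold higher number from compound 2 to compound 4 (0.61 log units; beyond the scatter). Set against the two-ring amine of compound 1, the 3-aminopyrrolidin-1-yl group gives a 1.9-fold higher number from compound 1 to compound 4 (0.28 log units; within the scatter), so the advantage of compound 2 over compound 1 is not retained once the aminomethyl group is shortened. Nothing available here explains the loss on shortening this group.

Still open, on these data alone, is whether a longer chain on the same ring carbon, such as 2-aminoethyl, would give a lower or a higher number than aminomethyl. The compounds shown also leave open whether a hydroxyl or hydroxymethyl group could replace the amine at this place.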